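Swapping the para substituent on the aryl ring: hydrogen to chlorine

The compounds below may be only part of what the source reports. "The series", "measured", "known", "first", "only" and "open" are said of these compounds alone.

Measured so far:
Compound 1 `COc1ccc(/C(C)=C(/C)C(=O)NC2CC2)cc1` gives 300 mg/kg in a toxicity assay on the whole organism (strain Icem-CET (SPF Caw)) for cytotoxicity, with Mus musculus as the target; a higher number here means that more compound is needed for the effect, a lower number that less compound is needed.
Compound 2 `C/C(C(=O)NC1CC1)=C(\C)c1ccccc1` gives 400 mg/kg in this assay.

For the measured compounds named here, compound 2 stands with the highest of the two numbers, and the only comparison that bears on it is a 1.3-fold higher number from compound 1 to compound 2 (0.12 log units; within the scatter), a step that stays within the scatter. Compound 3 `C/C(C(=O)NC1CC1)=C(\C)c1ccc(Cl)cc1` differs from compound 2 by chloro in place of hydrogen on an aromatic carbon, on an aromatic carbon para to a large group. Going by the values given here, the one measured change at that same position moved little, so no step beyond the scatter is expected, and the estimated step is a 1.1-fold lower number from compound 2 to compound 3 (0.06 log units; within the scatter). For compound 3 the expected value in this assay is 350 mg/kg, with a range from 150 mg/kg to 800 mg/kg.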

Compound 3, dose for half-maximal effect: 170 mg/kg
The estimate for compound 3 lay 2.1-fold (0.31 log units) above the measured number, within the range that was stated.
By their numbers in this assay, from the lowest: compounds 3, 1 and 2 (each within the scatter of the next, the first and the last beyond it).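

In this assay, the aromatic carbon para to a large group now shows a change beyond the scatter: chloro in place of hydrogen gives a 2.4-fold lower number from compound 2 to compound 3 (0.37 log units; beyond the scatter) in a modest step, unlike the earlier change at this position. Chloro in place of methoxy gives a 1.8-fold lower number from compound 1 to compound 3 (0.25 log units; within the scatter) and so does not separate these two groups. Nothing available explains the step.

As far as these compounds go, whether bromo, fluoro or an amine at this position would behave like chloro remains open, as does whether chloro would give the same step on a different amide.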